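Acetamido in place of hydrogen on the chalcone core

The source may hold more compounds than are shown below. What is called first, only, known or untested is meant among the compounds shown, and "the series" means these compounds.

Measured compounds:
Compound 1, `COc1ccc(/C=C/C(=O)c2ccc(N)c(-c3ccc(F)cc3)c2)cc1OC`, gives > 50000 nM in an assay on A549 cells for inhibition of transcription factor p65 (Homo sapiens), read by fluorescence, with a stated time of 2 h; a higher number here means a weaker inhibitor, a lower number a stronger inhibitor; this value is a limit of the assay, not a number.
Compound 2, `COc1ccc(/C=C/C(=O)c2cccc(-c3cccc(F)c3)c2)cc1OC`, gives 33400 nM in this assay.
Compound 3, `COc1ccc(/C=C/C(=O)c2cccc(-c3ccc(F)cc3)c2)cc1OC`, gives > 50000 nM in this assay; this too is a limit of the assay.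

Compound 3 thus stands at the ceiling of what this assay reports, a place shared with another value, because the limit of > 50000 nM in this assay, at which 2 of the 3 values shown sit, marks where two of the three values sit.

Compound 4, `COc1ccc(/C=C/C(=O)c2ccc(NC(C)=O)c(-c3ccc(F)cc3)c2)cc1OC`, has not yet been measured. It differs from compound 3 by acetamido in place of hydrogen on an aromatic carbon.

Within the data shown here, two measured steps touch compound 3. The step that the two limits leave unreadable from compound 1 to compound 3 cannot be sized, since both of its ends are limits. The step of an at least 1.4-fold higher number from compound 2 to compound 3 (0.17 log units; that floor lies within the scatter) has a floor lying within the scatter. Among the measured compounds shown here, neither step involves an acetamido group, so the present change has no measured counterpart here. Because compound 3 gives > 50000 nM, a limit, compound 4 is expected to stay near that ceiling. The step that the limit leaves unreadable from compound 3 to compound 4 is therefore expected to be small. Compound 4 is estimated at 60000 nM, with a range from 20000 nM to 150000 nM.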

Compound 4, half-maximal inhibitory concentration: 2650 nM
Estimate against measurement, compound 4: 23-fold (1.35 log units) above, outside the stated range (below it).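

Acetamido on this aromatic carbon, ortho to the 4-fluorophenyl group, is the first change here to produce a clear move in this assay, an at least 18-fold lower number from compound 3 to compound 4 (1.27 log units; beyond the scatter). The same compound also shows that the nitrogen alone does not account for this result, since acetyl in place of hydrogen on that nitrogen gives an at least 18-fold lower number from compound 1 to compound 4 (1.27 log units; beyond the scatter), so the amine and the acetamido group differ sharply at this position. The earlier comparison of hydrogen with amino could not show this, because compound 1 and compound 3 are both limits of the assay and that step cannot be read: the limit of > 50000 nM in this assay, at which 2 of the 4 values shown sit.

From the compounds shown here alone, it remains open whether a propionamide, a methanesulfonamide or a urea on the same nitrogen would behave like acetamido. Also open, going by these compounds, is whether acetamido would have a similar effect with the 3-fluorophenyl group of compound 2, which gives 33400 nM.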